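The source may report more compounds than this note shows. Statements on the series, on what has been measured and on what is new or still open speak of the compounds shown alone.

In an assay on isolated protein for binding affinity to sphingosine 1-phosphate receptor 2 (Homo sapiens), read by surface plasmon resonance (a lower number here means tighter binding, a higher number weaker binding), compound 2 `Cc1cc(NNC(=O)Nc2cc(Cl)nc(Cl)c2)nc2c1c(C)nn2C` gives 11000 nM, the higher of the two numbers recorded so far; compound 1 `Cc1nn(C)c2nc(NNC(=O)Nc3cc(Cl)nc(Cl)c3)cc(C3CC3)c12` gives 3650 nM. Among the compounds with values here, only one measured step bears on the next change: a 3.0-fold higher number from compound 1 to compound 2 (0.48 log units; beyond the scatter), a modest loss when the larger group gave way to methyl. Compound 3 `Cc1nn(C)c2nc(NNC(=O)Nc3cc(Cl)nc(Cl)c3)cc(-c3ccc(F)cc3)c12` carries 4-fluorophenyl in place of methyl on an aromatic carbon. Because a 3.0-fold higher number from compound 1 to compound 2 (0.48 log units; beyond the scatter) ran toward weaker binding, the reverse move to a larger group in compound 3 is expected to run the other way, as a 4.4-fold lower number from compound 2 to compound 3 (0.64 log units; beyond the scatter). For compound 3 the estimate in this assay is 2500 nM, with a range from 600 nM to 10000 nM.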

Compound 3, dissociation constant: 980 nM
Estimate against measurement, compound 3: 2.6-fold (0.41 log units) above, within the range that was stated.
By their numbers in this assay, from the lowest: compound 3; then compound 1; then compound 2.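

In this assay this aromatic carbon accepts a 4-fluorophenyl group, which gives an 11-fold lower number from compound 2 to compound 3 (1.05 log units; beyond the scatter) and also improves on cyclopropyl, with a 3.7-fold lower number from compound 1 to compound 3 (0.57 log units; beyond the scatter). Across these three compounds the number falls in the order methyl, cyclopropyl, 4-fluorophenyl, and all three steps lie beyond the scatter. Nothing available accounts for this order. As far as these compounds go, whether the gain depends on the aromatic ring or on its fluorine remains open, as plain phenyl would show. A pyridine ring or an amine such as morpholine at this carbon is also untested in the compounds shown here.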